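The compounds below may be only part of what the source reports. "The series", "measured", "known", "first", "only" and "open" are said of these compounds alone.

In a functional assay on RAW264.7 cells (Mus musculus) for inhibition, read by Griess assay, with a stated time of 20 h (a higher number here means a weaker inhibitor, a lower number a stronger inhibitor), three closely related compounds have been examined so far, and none of them has yet given a number. Among the compounds with values here, compound 1 `CC(C)CCc1cn(-c2ccc(O)c(C(=O)N3CCCCC3)c2)nn1` is the first of them. In this assay compound 1 gives only a limit of the assay, > 20000 nM. Compound 2 `CCCCCCc1cn(-c2ccc(O)c(C(=O)N3CCCCC3)c2)nn1` differs from compound 1 by butyl in place of isopropyl on a saturated chain carbon, two bonds along the chain from an aromatic carbon. In this assay compound 2 likewise gives only a limit, > 20000 nM. The step that the two limits leave unreadable from compound 1 to compound 2 cannot be read: both of its ends are limits. Compound 3 `CCCNC(=O)c1ccc(-n2cc(CCC(C)C)nn2)cc1O` is built on a different core; the difference between the core of compound 3 and the core of compound 1 is not broken down here. In this assay compound 3 also gives only a limit, > 20000 nM.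

The unmeasured compound 4 `CCCCCCc1cn(-c2ccc(C(=O)NCCC)c(O)c2)nn1` stands to compound 3 exactly as compound 2 stands to compound 1: the change is butyl in place of isopropyl on a saturated chain carbon, two bonds along the chain from an aromatic carbon, the same change at the same place. Within the data shown here, the only evidence bearing on this change is the limit of > 20000 nM in this assay, at which 3 of the 3 values shown sit, and it gives no direction and no size for the step. The step is therefore expected to be a step that the limit leaves unreadable from compound 3 to compound 4, an expectation that rests on the limit of > 20000 nM in this assay, at which 3 of the 3 values shown sit, and on the unreadable step that the two limits leave unreadable from compound 1 to compound 2. Compound 4 is thus expected to come out around 30000 nM, most probably once more as a limit rather than a number, with a range estimated from 15000 nM to 100000 nM.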

Compound 4, half-maximal inhibitory concentration: > 20000 nM
Compound 4 ended at the assay's limit; the forecaster's own chance of this, stated with the estimate: 85%; the middle value lies beyond the limit too.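

In this assay compound 4 gives > 20000 nM as a limit of the assay and not a number. Compound 3 also stands at a limit, so no new step can be read between compound 3 and compound 4. The compounds shown leave open how strongly any of them inhibits and whether butyl in place of isopropyl moves the read-out in either direction, with only this to go on: the limit of > 20000 nM in this assay, at which 4 of the 4 values shown sit.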